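The compounds below may be only part of what the source reports. "The series", "measured", "known", "first", "only" and "open" are said of these compounds alone.

Compound 1 `CC(C)C[C@H](N)c1cc(C(F)(F)F)ccc1N1CCN(C(=O)CCc2cccc(C(F)(F)F)c2)CC1` gives 2200 nM in an assay on HEK293 cells for displacement of a labelled ligand from Melanocortin receptor 4 (Homo sapiens); a lower number here means a stronger inhibitor, a higher number a weaker inhibitor. Compound 2 `CC(C)C[C@H](N)c1cc(C(F)(F)F)ccc1N1CCN(C(=O)CCc2ccc(O)cc2)CC1` reaches only the limit > 10000 nM in this assay. Compound 3 `COc1ccc(OC)c(CCC(=O)N2CCN(c3ccc(C(F)(F)F)cc3[C@@H](N)CC(C)C)CC2)c1` gives 2500 nM in this assay.

Among the two numbers, compound 3 stands highest; its nearest neighbour is compound 1, a 1.1-fold higher number from compound 1 to compound 3 (0.06 log units; within the scatter). The sole limit is the limit of > 10000 nM in this assay, at which 1 of the 3 values shown sits.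

Compound 4 `COc1cc(OC)c(OC)cc1CCC(=O)N1CCN(c2ccc(C(F)(F)F)cc2[C@@H](N)CC(C)C)CC1` differs from compound 3 by methoxy in place of hydrogen on an aromatic carbon. For the measured compounds named here, no measured step adds a substituent to an already substituted aryl ring; the nearest guides are the aryl swaps a 1.1-fold higher number from compound 1 to compound 3 (0.06 log units; within the scatter) and an at least 4.0-fold lower number from compound 2 to compound 3 (0.60 log units; beyond the scatter), which show a hydroxyl-bearing ring losing and a dimethoxy ring holding. A third methoxy is expected to give no change at the digits printed from compound 3 to compound 4 (within the scatter) in this assay, nothing beyond the scatter. Compound 4 is estimated at 2500 nM, between 1000 nM and 8000 nM.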

Compound 4, inhibition constant: 6100 nM
Beside the measured number, compound 4's estimate is 2.4-fold (0.39 log units) below it; the range from low to high includes it.
By their numbers in this assay, from the lowest: compounds 1 and 3 (each within the scatter of the next); then compound 4. At a limit, above all of these: compound 2.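

In this assay, for the compounds shown here, methoxy in place of hydrogen on the dimethoxy ring, para to a large group, is the first ring addition and it weakens binding, with a 2.4-fold higher number from compound 3 to compound 4 (0.39 log units; beyond the scatter) as the step. The 2,4,5-trimethoxyphenyl ring also separates from the 3-(trifluoromethyl)phenyl ring, with a 2.8-fold higher number from compound 1 to compound 4 (0.44 log units; beyond the scatter), whereas the 2,5-dimethoxyphenyl ring stayed within the scatter of it. Against the 4-hydroxyphenyl ring the reading is an at least 1.6-fold lower number from compound 2 to compound 4 (0.21 log units; that floor lies within the scatter), and it rests on a limit: the limit of > 10000 nM in this assay, at which 1 of the 4 values shown sits.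

Open, going by these compounds, is whether a hydroxyl, a fluorine or an amine at this place would follow methoxy. Also open, on these data alone, is whether the step holds on a ring lacking the other methoxy groups.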